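Trifluoromethyl to chloro in the series: working notes

A few compounds are considered here, and "the series" means these few. Any claim that something is new, unique, unknown or untested is made for them only; others in the source may bear on it.

Measured in a functional assay on RAW264.7 cells (Mus musculus), with a stated time of 3 days; on this read-out lower numbers stand for stronger inhibition and higher numbers for weaker inhibition:
compound 1 `COc1cnc(-c2ccccn2)nc1N(C)C1CCCC1` gives 180 nM
compound 2 `COc1cnc(-c2ccccn2)nc1NCc1ccccc1C(F)(F)F` gives 230 nM
compound 3 `COc1cnc(-c2ccccn2)nc1NC(C)c1ccccc1` gives 660 nM

Compound 2 at 230 nM lies within the scatter of compound 1, so these two cannot be ranked against each other. Compound 3 at 660 nM shows weaker inhibition than compound 2, and that gap lies beyond the scatter.

The next entry is compound 4 `COc1cnc(-c2ccccn2)nc1NCc1ccccc1Cl`, not yet measured. Its difference from compound 2 is chloro in place of trifluoromethyl on an aromatic carbon; this is chloro in place of trifluoromethyl on an aromatic carbon, ortho to a large group. Going by the values given here, no measured pair in this small set isolates that change, so the data give no direct size for it.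

In this assay a small step is expected, with none beyond the scatter and no firm direction. Among the compounds with values here, the only guide is indirect: compound 1 at 180 nM and compound 2 carry quite different groups on the shared core yet stay within the scatter of each other, although compound 3 goes against this picture.

The expected step is a 1.2-fold higher number from compound 2 to compound 4 (0.09 log units; within the scatter) and remains an estimate. For compound 4 the estimated value is 280 nM, with an expected range from 110 nM to 700 nM until the measurement is in.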

Compound 4, half-maximal inhibitory concentration: 520 nM
For compound 4 the middle estimate is 1.9-fold (0.27 log units) below the measured one, and the stated range covers the measured number.
By their numbers in this assay, from the lowest: compounds 1 and 2 (each within the scatter of the next); then compounds 4 and 3 (each within the scatter of the next).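

In this assay chloro in place of trifluoromethyl on an aromatic carbon, ortho to a large group, gives a 2.3-fold higher number from compound 2 to compound 4 (0.35 log units; beyond the scatter) as the first direct size for this change in the series. The earlier compounds shown here held no pair that isolated this position, and this pair shows that the group placed here can move the number beyond the scatter, though the step is modest and it comes from a single pair. The exchange replaces 4 heavy atoms with 1, with 0 hydrogen-bond donors, 0 hydrogen-bond acceptors and no net charge on either group, and no measurement at hand explains the step, so its cause remains unassigned.

The compounds shown leave open how a fluoro, methyl, methoxy or nitrile group at this same place would compare with trifluoromethyl and chloro, so one pair does not yet define a trend for this position. They also leave open whether the same exchange would give a step of similar size and direction with a different amine on the shared core, such as a longer chain in place of the benzylic amine.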